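A few compounds are considered here, and "the series" means these few. Any claim that something is new, unique, unknown or untested is made for them only; others in the source may bear on it.

Working notes on the series.

Of the compounds shown here, three sharing one core have been measured in a functional assay on MGC-803 cells (Homo sapiens) for inhibition, read by sulforhodamine B assay; a higher number here means a weaker inhibitor, a lower number a stronger inhibitor. Compound 1 `O=C1C=C(NCc2ccccc2)C(=O)c2c1nc1n2[C@H]2OC[C@@H](O)[C@H]2OC1` gives 2670 nM. Compound 2 `CCc1ccc(NC2=CC(=O)c3nc4n(c3C2=O)[C@H]2OC[C@@H](O)[C@H]2OC4)cc1` gives 1290 nM, and compound 3 `CCCc1ccc(NC2=CC(=O)c3nc4n(c3C2=O)[C@H]2OC[C@@H](O)[C@H]2OC4)cc1` gives 1560 nM. Among these three numbers compound 3 stands second highest; it sits close to compound 2 and further from compound 1, yet both gaps are within the scatter. Going by the values given here, the only step beyond the scatter is a 2.1-fold lower number from compound 1 to compound 2 (0.32 log units; beyond the scatter); the parallel step a 1.7-fold lower number from compound 1 to compound 3 (0.23 log units; within the scatter) is within it, as is a 1.2-fold higher number from compound 2 to compound 3 (0.08 log units; within the scatter).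

The next compound, compound 4 `O=C1C=C(Nc2ccccc2F)C(=O)c2c1nc1n2[C@H]2OC[C@@H](O)[C@H]2OC1`, differs from compound 3 in one place: 2-fluorophenyl in place of 4-propylphenyl on an amine nitrogen. Among the compounds with values here, no measured step exchanges one aryl group for another that is substituted differently, so the only guidance is indirect: the step from compound 2 to compound 3 shows that a change of substituent on this aryl ring moved the number little. A step within the scatter is therefore expected, a 1.3-fold higher number from compound 3 to compound 4 (0.11 log units; within the scatter), with no clear direction. Compound 4 is expected to give about 2000 nM, within 900 nM to 4500 nM.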

Compound 4, half-maximal inhibitory concentration: 2080 nM
Estimate against measurement, compound 4: 1.0-fold (0.02 log units) below; the range from low to high includes it.
By their numbers in this assay, from the lowest: compounds 2, 3, 4 and 1 (each within the scatter of the next, the first and the last beyond it).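

In this assay, 2-fluorophenyl on the amine nitrogen stays within the scatter of both alkyl-substituted aryl groups, with a 1.3-fold higher number from compound 3 to compound 4 (0.12 log units; within the scatter) and a 1.6-fold higher number from compound 2 to compound 4 (0.21 log units; within the scatter), so removing the alkyl chain and adding a fluorine to the aryl ring does not shift the number measurably. Against benzyl the result is a 1.3-fold lower number from compound 1 to compound 4 (0.11 log units; within the scatter), also within the scatter, so 2-fluorophenyl does not reproduce the one step beyond the scatter, a 2.1-fold lower number from compound 1 to compound 2 (0.32 log units; beyond the scatter), although the gap between those two steps cannot be judged here. No independent data accompany these numbers to account for them.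

Going by these compounds, it remains open whether any group on this nitrogen can move the number far from this narrow band. A phenyl ring carrying a carboxylic acid, an amine or a much longer alkyl chain would test that.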